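The source may hold more compounds than are shown below. What is called first, only, known or untested is meant among the compounds shown, and "the series" means these compounds.

Measured in a functional assay on SK-LU-1 cells (Homo sapiens) for cytotoxicity, read by sulforhodamine B assay, with a stated time of 48 h; a higher number here means a weaker inhibitor, a lower number a stronger inhibitor:
- compound 1 `Cc1ccc(Nc2nccc(-c3c(C)nc4ccccn34)n2)cc1`: 19.7 nM
- compound 2 `Cc1nc2ccccn2c1-c1ccnc(Nc2ccc(C=O)s2)n1`: 1540 nM

Compound 1 holds the lower of the two numbers, so it is the stronger inhibitor of this pair. Compound 3 `Cc1nc2ccccn2c1-c1ccnc(Nc2ccc(C(F)(F)F)cc2)n1` has not yet been measured. It keeps the core of compound 1 but has trifluoromethyl in place of methyl on an aromatic carbon, para to a large group: trifluoromethyl in place of methyl on an aromatic carbon. Among the measured compounds shown here, only one measured step bears on this, and only indirectly. That large step, a 78-fold higher number from compound 1 to compound 2 (1.89 log units; beyond the scatter), swapped the whole 4-methylphenyl for 5-formylthiophen-2-yl, so this part of the molecule can matter in this assay. Compound 3 changes only the small group on that ring, so a much smaller step is expected, probably towards a higher number: a 2.5-fold higher number from compound 1 to compound 3 (0.40 log units; beyond the scatter). For compound 3 the estimated value is 50 nM, with an expected range from 10 nM to 250 nM.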

Compound 3, half-maximal inhibitory concentration: 34 nM
Compound 3: the middle estimate sits 1.5-fold (0.17 log units) above what was measured; low and high end bracket the measured number.
By their numbers in this assay, from the lowest: compounds 1 and 3 (each within the scatter of the next); then compound 2.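

In this assay, trifluoromethyl in place of methyl on the aromatic carbon gives a 1.7-fold higher number from compound 1 to compound 3 (0.24 log units; within the scatter) and so leaves the two compounds indistinguishable in this assay. The earlier comparison replaced the whole 4-methylphenyl and showed only that this part of the molecule can matter, whereas this pair shows that the small group on that ring can be exchanged for one with more heavy atoms, including fluorine, without a step beyond the scatter. No measurement at hand explains this result.

The compounds shown leave open whether other groups at this place, such as an amine, a carboxylic acid or a longer chain, would behave the same way. Compound 2 changes the ring and its small group together, so the effects of those two changes remain unseparated.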